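One Ring Swapped on Compound 2

A few compounds are considered here, and "the series" means these few. Any claim that something is new, unique, unknown or untested is made for them only; others in the source may bear on it.

In an ADME assay on NIH3T3 cells (Mus musculus) for cytotoxicity (a higher number here means that more compound is needed for the effect, a lower number that less compound is needed), compound 1 (`Cc1ccccc1Oc1cccc(Cn2ccnc2)c1`) gives 79300 nM. Compound 2 (`Cc1cc(Oc2cccc(Cn3ccnn3)c2)cc(C)c1Cl`) gives 66800 nM, which lies within the usual scatter of the value for compound 1, so these two numbers cannot be told apart.

Compound 3 (`Cc1cc(Oc2cccc(Cn3cccn3)c2)cc(C)c1Cl`) has not yet been measured. It differs from compound 2 in one place, with 1H-pyrazol-1-yl in place of 1H-1,2,3-triazol-1-yl on a saturated chain carbon bound to an aromatic carbon. Cut one bond further out, the same difference reads (1H-1,2,3-triazol-1-yl)methyl to (1H-pyrazol-1-yl)methyl.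

Within the data shown here, no measured pair shows the effect of this swap, so there is no direct precedent for it. Among the measured compounds shown here, the only guide is that the two known numbers in this assay sit close together, with compound 1 at 79300 nM and compound 2 at 66800 nM. On that thin evidence, no step beyond the scatter is expected. The estimated change is a 1.1-fold lower number from compound 2 to compound 3 (0.05 log units; within the scatter). Compound 3 is estimated at 60000 nM, with an expected range of 27000 nM to 120000 nM.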

Compound 3, half-maximal effective concentration: > 100000 nM
Compound 3: only a limit was reported; the forecaster's own chance of this, stated with the estimate: 15%; middle value at least 1.6-fold (0.22 log units) away from the limit.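

Among these compounds, this is the first look at what happens on the saturated chain carbon bound to an aromatic carbon when the rest of the molecule stays fixed. There, in this assay, replacing 1H-1,2,3-triazol-1-yl, a five-membered aromatic ring with 3 hetero atoms, by 1H-pyrazol-1-yl, one with 2 hetero atoms, gives an at least 1.4-fold higher number from compound 2 to compound 3 (0.17 log units; that floor lies within the scatter). Compound 3 reads > 100000 nM, and this is a limit of the assay, not a number. The swap therefore gives no sign of a lower number, but the floor of the step does not by itself establish a real rise, and the true size stays unknown because the reading stops at the limit: the limit of > 100000 nM in this assay, at which 1 of the 3 values shown sits.

The compounds shown leave open whether a different kind of group at this place, such as an amine or a carboxylic acid, or a longer chain in place of the single chain carbon, would change the number. Among the compounds shown here, with only this one pair carrying the swap, they also leave open whether it would act the same way on the core of compound 1.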